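Swapping tert-butyl for chloro: from compound 3 to compound 4

The source may hold more compounds than are shown below. What is called first, only, known or untested is meant among the compounds shown, and "the series" means these compounds.

compound 1 `CCc1ccc(NS(=O)(=O)c2ccc(N3CCNC3=O)cc2)cc1`: 810 nM
compound 2 `CCCCCCOc1ccc(NS(=O)(=O)c2ccc(N3CCNC3=O)cc2)cc1`: > 1000 nM
compound 3 `CC(C)(C)c1ccc(NS(=O)(=O)c2ccc(N3CCNC3=O)cc2)cc1`: > 1000 nM

In a functional assay on MCF7 cells (Homo sapiens) for antiproliferative activity, read by sulforhodamine B assay, with a stated time of 48 h (a lower number here means a stronger inhibitor, a higher number a weaker inhibitor), compound 1 gives 810 nM. For compound 2 the read-out is only a limit of the assay, > 1000 nM. For compound 3 the read-out is likewise only a limit, > 1000 nM. Compound 3 thus stands at the ceiling of the series (the limit of > 1000 nM in this assay, at which 2 of the 3 values shown sit). The step with ethyl replaced by tert-butyl was an at least 1.2-fold higher number from compound 1 to compound 3 (0.09 log units; that floor lies within the scatter), and the step with hexyloxy replaced by tert-butyl was a step that the two limits leave unreadable from compound 2 to compound 3.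

Compound 4 `O=C1NCCN1c1ccc(S(=O)(=O)Nc2ccc(Cl)cc2)cc1` differs from compound 3 by chloro in place of tert-butyl on an aromatic carbon. For the measured compounds named here, no measured step involves a chloro group, so the direction can only be judged from the one numeric value, that of compound 1, whose ethyl group is the smallest substituent measured so far. Chloro is smaller still, and the step back down from the limit is expected to be at least modest, with no more than a small reversal beyond the scatter predicted. Compound 4 is estimated at 900 nM, with a range from 400 nM to 3000 nM. This rests on the fact that compound 1 gives 810 nM with a small alkyl group at the same position. The expected change is therefore an at least 1.1-fold lower number from compound 3 to compound 4 (0.04 log units; that floor lies within the scatter).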

Compound 4, half-maximal inhibitory concentration: 170 nM
For compound 4 the middle estimate is 5.3-fold (0.72 log units) above the measured one, and the stated range ends above it.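

In this assay, the place on the six-membered aromatic ring para to a large group now shows a change beyond the scatter between two true numbers: chloro in place of ethyl gives a 4.8-fold lower number from compound 1 to compound 4 (0.68 log units; beyond the scatter). Chloro also stands clearly apart from the two other groups at this place, with an at least 5.8-fold lower number from compound 3 to compound 4 (0.76 log units; beyond the scatter) when it replaces tert-butyl and an at least 5.8-fold lower number from compound 2 to compound 4 (0.76 log units; beyond the scatter) when it replaces hexyloxy. Compound 2 and compound 3 each read only as a limit, so these last two steps give only a floor and their full size remains unknown: the limit of > 1000 nM in this assay, at which 2 of the 4 values shown sit.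

From the compounds shown here alone, whether fluoro, bromo or a methyl group at this place would read like chloro stays open, and so does the reading of an amine or a carboxylic acid there. All four compounds share the same core and differ at this one place only, so they also leave open whether any change elsewhere in the core would alter the reading in this assay.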